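Working notes: from compound 2 to compound 4

A few compounds are considered here, and "the series" means these few. Any claim that something is new, unique, unknown or untested is made for them only; others in the source may bear on it.

Values in an ADME assay on cells (Hepatocyte, Rattus norvegicus, strain Wistar) for pharmacokinetics, read by LC-MS, with a stated time of 90 min, tested at 1 uM (a lower number here means slower removal, a higher number faster removal of the compound), so far:
- compound 1 `CCCN(CC1CCOC1)C(=O)c1cc(OC)c2oc(NCc3cccc(Cl)c3)nc2c1` gives 65 mL/min/kg
- compound 2 `COc1cc(C(=O)N2CCC(O)CC2)cc2nc(NCc3cccc(Cl)c3)oc12` gives 21.7 mL/min/kg
- compound 3 `COc1cc(C(=O)N2CC[C@@H](O)[C@H](C)C2)cc2nc(NCc3cccc(Cl)c3)oc12` gives 38.3 mL/min/kg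

Compound 2 stands at the low end of these numbers, with one step beyond the scatter (a 3.0-fold lower number from compound 1 to compound 2 (0.48 log units; beyond the scatter)) and one within it (a 1.8-fold higher number from compound 2 to compound 3 (0.25 log units; within the scatter)). Compound 4 `COc1cc(C(=O)N2CC(C)C(O)CC2CCO)cc2nc(NCc3cccc(Cl)c3)oc12` is unmeasured and carries 4-hydroxy-2-(2-hydroxyethyl)-5-methylpiperidin-1-yl in place of 4-hydroxypiperidin-1-yl on a carbonyl carbon. The nearest guide is methyl in place of hydrogen on a saturated ring carbon (a 1.8-fold higher number from compound 2 to compound 3 (0.25 log units; within the scatter)), which stays within the scatter. Within the data shown here, no measured step tests the 2-hydroxyethyl group. The expected step in this assay (a 1.3-fold higher number from compound 2 to compound 4 (0.11 log units; within the scatter)) is therefore towards a higher number but not beyond the scatter. Compound 4 is estimated at 28 mL/min/kg (range 14 mL/min/kg to 55 mL/min/kg).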

Compound 4, clearance: 4.5 mL/min/kg
Estimate against measurement, compound 4: 6.2-fold (0.79 log units) above; measured number outside the range, below it.
By their numbers in this assay, from the lowest: compound 4; then compounds 2, 3 and 1 (each within the scatter of the next, the first and the last beyond it).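

In this assay, the group on the carbonyl carbon can shift the number well beyond the scatter, as a 4.8-fold lower number from compound 2 to compound 4 (0.68 log units; beyond the scatter) shows, while methyl in place of hydrogen gave only a 1.8-fold higher number from compound 2 to compound 3 (0.25 log units; within the scatter). The 4-hydroxy-2-(2-hydroxyethyl)-5-methylpiperidin-1-yl group also stands clear of the other two amides, with an 8.5-fold lower number from compound 3 to compound 4 (0.93 log units; beyond the scatter) and a 14-fold lower number from compound 1 to compound 4 (1.16 log units; beyond the scatter). No available evidence bears on the reason for this drop.

The compounds shown do not separate the contribution of the 2-hydroxyethyl group from that of the methyl group in compound 4. On these data alone, whether a 3-hydroxypropyl chain or a carboxylic acid at that place would hold the low number remains open.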